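The source may report more compounds than this note shows. Statements on the series, on what has been measured and on what is new or still open speak of the compounds shown alone.

Measured so far in a functional assay on KB cells (Homo sapiens) for antiproliferative activity, read by MTT assay, with a stated time of 72 h; on this read-out higher numbers stand for weaker inhibition and lower numbers for stronger inhibition:
compound 1 `O=C1C=C(N2CCN(c3ccccc3)CC2)C(=O)c2c(O)ccc(O)c21` gives 1400 nM
compound 2 `O=C1C=C(N2CCC(c3ccccc3)CC2)C(=O)c2c(O)cccc21` gives 2200 nM

Compound 2 at 2200 nM stands within the usual scatter of compound 1 at 1400 nM and the two numbers do not separate. Among the measured compounds shown here, these two structures differ in more than one place, and no measured pair differs in one place only.

Not yet measured is compound 3 `O=C1C=C(N2CCC(c3ccc(Cl)cc3)CC2)C(=O)c2c(O)cccc21` which is compound 2 with chloro in place of hydrogen on an aromatic carbon, para to a large group, so that phenyl becomes 4-chlorophenyl. For the measured compounds named here, the counted difference reads chloro in place of hydrogen on an aromatic carbon and nothing measured so far gives a size for this change.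

In this assay no step beyond the scatter is expected, with only a slight lean toward lower numbers (the estimate means a 1.5-fold lower number from compound 2 to compound 3 (0.17 log units; within the scatter)) and this lean is a judgement and not a measured trend. The estimated value for compound 3 is 1500 nM with an expected range from 600 nM to 3800 nM in the same read-out.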

Compound 3, half-maximal inhibitory concentration: 14000 nM
Beside the measured number, compound 3's estimate is 9.3-fold (0.97 log units) below it; measured number outside the range, above it.
By their numbers in this assay, from the lowest: compounds 1 and 2 (each within the scatter of the next); then compound 3.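

In this assay, among the compounds shown here, the change from phenyl to 4-chlorophenyl gives a 6.4-fold higher number from compound 2 to compound 3 (0.80 log units; beyond the scatter), the only step so far that can be read at a single place, and it lies beyond the scatter. The aromatic carbon para to a large group is therefore not a neutral place for substitution in this series: chloro in place of hydrogen there, a change of one heavy atom with no ring, no hydrogen-bond donor or acceptor and no net charge, is enough to shift the read-out toward weaker inhibition. Nothing available on these compounds speaks to what lies behind this step, so it stands as an observation only.

Still open, from the compounds shown here alone, is whether this shift belongs to chloro itself or would follow any replacement of hydrogen at this place, a question that fluoro, methoxy or an amine on the same aromatic carbon would address. Also open, going by these compounds, is whether chloro at the matching place would give a similar step on the core of compound 1, which differs from compound 2 in more than one place.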